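A few compounds are considered here, and "the series" means these few. Any claim that something is new, unique, unknown or untested is made for them only; others in the source may bear on it.

Measured in a functional assay on NCI-H460 cells (Homo sapiens) for antiproliferative activity, read by sulforhodamine B assay, with a stated time of 48 h; a higher number here means a weaker inhibitor of growth, a lower number a stronger inhibitor of growth:

compound 1 `COc1ccc2cc(CCCO)oc(=O)c2c1` gives 29.1 ug/mL
compound 2 `CCCCCOCCCc1cc2ccc(OC)cc2c(=O)o1` gives 32 ug/mL
compound 3 `COc1ccc2c(c1)C(=O)OC(CCCO)C2` gives 136 ug/mL

Compound 1 and compound 2 share a core and differ by pentyl in place of hydrogen on an oxygen on a saturated carbon; this step reads a 1.1-fold higher number from compound 1 to compound 2 (0.04 log units; within the scatter). Compound 3 carries a different core; how the two cores differ is not broken down here. Compound 3 stands furthest from compound 1 and compound 2, both steps to it lying beyond the scatter.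

Compound 4 `CCCCCOCCCC1Cc2ccc(OC)cc2C(=O)O1` is not yet measured. It differs from compound 3 by pentyl in place of hydrogen on an oxygen on a saturated carbon, the same change as that from compound 1 to compound 2, at the same kind of place. The expectation for compound 4 in this assay rests on compound 3 and on that earlier step, which was within the scatter; the step from compound 3 to compound 4 is expected to read a 1.1-fold higher number from compound 3 to compound 4 (0.03 log units; within the scatter). Compound 4 is therefore estimated at 145 ug/mL, plausibly between 70 ug/mL and 300 ug/mL.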

Compound 4, concentration for 50% growth inhibition: 33.7 ug/mL
Compound 4: the middle estimate sits 4.3-fold (0.63 log units) above what was measured; the measured number lies below the stated range.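

On the core of compound 3, pentyl in place of hydrogen on the oxygen gives a 4.0-fold lower number from compound 3 to compound 4 (0.61 log units; beyond the scatter) in this assay. With a single pair on each core, this does not show why the cores part, nor how the change would read on a further core. The change therefore cannot be carried as a fixed step between these two cores, as the two pairs differ: the same change on two cores in this assay, a 1.1-fold higher number (0.04 log units; within the scatter) from compound 1 to compound 2 and a 4.0-fold lower number (0.61 log units; beyond the scatter) from compound 3 to compound 4, 4.4-fold (0.65 log units) apart, beyond the scatter of two such steps

Still open, from the compounds shown here alone, is whether a butyl or a longer chain on that oxygen would follow the pattern of the core of compound 1 or that of compound 3. Equally open, going by these compounds, is how an amine in place of the hydroxy would read on either core.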